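A few compounds are considered here, and "the series" means these few. Any claim that something is new, unique, unknown or untested is made for them only; others in the source may bear on it.

Compound 1 `CC(C)[C@H](NC(=O)c1cc(Cl)ccc1OCCCNC(=O)OC(C)(C)C)C(=O)Nc1ccc([N+](=O)[O-])cc1Cl` carries a tert-butoxycarbonyl on an amine nitrogen. In a functional assay on MDA-MB-231 cells (Homo sapiens) for inhibition, read by MTT assay, with a stated time of 72 h (a lower number here means a stronger inhibitor, a higher number a weaker inhibitor), compound 1 reaches only the assay limit of > 10000 nM, a limit rather than a number. Compound 2 `CC(C)[C@H](NC(=O)c1cc(Cl)ccc1OCCCN)C(=O)Nc1ccc([N+](=O)[O-])cc1Cl` gives 6770 nM in this assay. The change between them, (hydrogen in place of tert-butoxycarbonyl on an amine nitrogen), made a step of an at least 1.4-fold lower number from compound 1 to compound 2 (0.16 log units; that floor lies within the scatter). Compound 3 `CC(C)C[C@H](NC(=O)c1cc(Cl)ccc1OCCNC(=O)OC(C)(C)C)C(=O)Nc1ccc([N+](=O)[O-])cc1Cl` likewise sits at the assay limit of > 10000 nM in this assay. The difference between the cores of compound 1 and compound 3 is not broken down here. Compound 4 `CC(C)C[C@H](NC(=O)c1cc(Cl)ccc1OCCN)C(=O)Nc1ccc([N+](=O)[O-])cc1Cl` arises from compound 3 by the same change, (hydrogen in place of tert-butoxycarbonyl on an amine nitrogen). Its expected step is an at least 1.4-fold lower number from compound 3 to compound 4 (0.15 log units; that floor lies within the scatter), resting on the earlier at least 1.4-fold lower number from compound 1 to compound 2 (0.16 log units; that floor lies within the scatter) and on (the limit of > 10000 nM in this assay, at which 2 of the 3 values shown sit), at which compound 3 also sits. Compound 4 is therefore estimated at 7000 nM, between 3000 nM and 20000 nM.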

Compound 4, half-maximal inhibitory concentration: > 10000 nM
Compound 4 gave a limit, no number (the forecaster's own chance of this, stated with the estimate: 40%); middle value at least 1.4-fold (0.15 log units) away from the limit.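

Compound 3 and compound 4 both stand at a limit of the assay, not at a number, and no step can be read between them. The compounds shown leave open whether hydrogen in place of tert-butoxycarbonyl changes the value at all on the core of compound 3.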